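The source may hold more compounds than are shown below. What is called first, only, known or untested is meant among the compounds shown, and "the series" means these compounds.

Of the compounds shown here, three sharing one core have been tested in a functional assay on CHO-K1 cells for antagonist activity at transient receptor potential cation channel subfamily V member 1 (Homo sapiens), read by FLIPR; a lower number here means a stronger inhibitor, a higher number a weaker inhibitor. Compound 1 `CC(C(=O)NCc1ccc(C(F)(F)F)nc1NC1CCCCC1)c1ccc(NS(C)(=O)=O)c(F)c1` gives 260 nM, the highest number among the three. Compound 2 `Cc1ccc(Cl)cc1Nc1nc(C(F)(F)F)ccc1CNC(=O)C(C)c1ccc(NS(C)(=O)=O)c(F)c1` gives 140 nM, and the step of a 1.9-fold lower number from compound 1 to compound 2 (0.27 log units; within the scatter) stays within the scatter. Compound 3 `CCCCOC1CCN(c2nc(C(F)(F)F)ccc2CNC(=O)C(C)c2ccc(NS(C)(=O)=O)c(F)c2)CC1` gives 28.2 nM, and the step of a 9.2-fold lower number from compound 1 to compound 3 (0.96 log units; beyond the scatter) is a modest gain.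

Compound 4 `CC(C(=O)NCc1ccc(C(F)(F)F)nc1N1CCCCCC1)c1ccc(NS(C)(=O)=O)c(F)c1` has not yet been measured in this assay . It differs from compound 1 in one place: azepan-1-yl in place of cyclohexylamino on an aromatic carbon. The ring-bound nitrogen of compound 3 also carries no hydrogen, and that change helped, whereas the change to compound 2 did not. A small gain is therefore expected, smaller than that of compound 3 because compound 3 brings more with a 9.2-fold lower number from compound 1 to compound 3 (0.96 log units; beyond the scatter). The estimate for compound 4 is 110 nM, between 40 nM and 300 nM, an expected step of a 2.4-fold lower number from compound 1 to compound 4 (0.37 log units; beyond the scatter).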

Compound 4, half-maximal inhibitory concentration: 25.1 nM
Compound 4: the middle estimate sits 4.4-fold (0.64 log units) above what was measured, outside the stated range (below it).
By their numbers in this assay, from the lowest: compounds 4 and 3 (each within the scatter of the next); then compounds 2 and 1 (each within the scatter of the next).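

Rearranging the same heavy atoms into azepan-1-yl, which leaves no hydrogen-bond donor on the attached nitrogen, gives a 10-fold lower number from compound 1 to compound 4 (1.02 log units; beyond the scatter), so at this position the arrangement of the atoms counts, not just their number. Group size alone does not decide the result: a 1.1-fold lower number from compound 3 to compound 4 (0.05 log units; within the scatter), despite the smaller group in compound 4, while a 5.6-fold lower number from compound 2 to compound 4 (0.75 log units; beyond the scatter). Nothing measured here explains the change.

The compounds shown do not separate the loss of the nitrogen hydrogen from the change to a seven-membered ring. Unsubstituted piperidin-1-yl and cycloheptylamino at this position would pull those two changes apart.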